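Working notes: from compound 2 to compound 4

The source may report more compounds than this note shows. Statements on the series, on what has been measured and on what is new or still open speak of the compounds shown alone.

Measured in a functional assay on K562 cells (Homo sapiens) for antiproliferative activity, read by CCK-8 assay, with a stated time of 72 h; a higher number here means a weaker inhibitor of growth, a lower number a stronger inhibitor of growth:
- compound 1 `CC[C@@H]1C(=O)N(C)c2cnc(Nc3ccc(S(=O)(=O)Nc4ccccc4)cc3)nc2N1C1CCCC1`: 4180 nM
- compound 2 `CCCNC(=O)c1ccc2c(ccn2-c2ncc3c(n2)N(c2ccn(C)n2)C(CC)C(=O)N3C)c1`: 8270 nM
- compound 3 `CC[C@@H]1C(=O)N(C)c2cnc(Nc3ccc(S(=O)(=O)NC4CCCC4)cc3)nc2N1C1CCCC1`: 872 nM

Compound 2 gives 8270 nM, within the scatter of compound 1 at 4180 nM. Compound 3 at 872 nM lies lower than compound 2, beyond the scatter.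

The next compound is compound 4 `CCC1C(=O)N(C)c2cnc(-n3ccc4cc(C(=O)NCC(C)C)ccc43)nc2N1c1ccn(C)n1`. Its difference from compound 2 is methyl in place of hydrogen on a saturated chain carbon bound to two saturated chain carbons, and the same difference reads propyl to isobutyl.

Among the measured compounds shown here, only one measured step is available, a 4.8-fold lower number from compound 1 to compound 3 (0.68 log units; beyond the scatter). It is modest and involves a different change at a sulfonamide nitrogen, so it offers only a rough guide to scale. For the measured compounds named here, no measured pair changes the propyl chain, and the data show no direction for this change. A step beyond the scatter in this assay is therefore not expected.

The expected step is a 1.2-fold lower number from compound 2 to compound 4 (0.07 log units; within the scatter), which is an estimate and carries no firm direction. For compound 4 the estimated value is 7000 nM, with an expected range of 2500 nM to 20000 nM.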

Compound 4, concentration for 50% growth inhibition: 5600 nM
The estimate for compound 4 lay 1.3-fold (0.10 log units) above the measured number; low and high end bracket the measured number.
By their numbers in this assay, from the lowest: compound 3; then compounds 1, 4 and 2 (each within the scatter of the next).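

Among the compounds shown here, replacing hydrogen with methyl on a saturated chain carbon bound to two saturated chain carbons, which turns propyl into isobutyl, gives the first measured step at this chain in this assay: a 1.5-fold lower number from compound 2 to compound 4 (0.17 log units; within the scatter). This single added carbon therefore produces no change that can be read in this assay, so this one pair gives no direction for the change. Nothing measured here bears on this result.

Going by these compounds, it remains open whether a longer chain such as pentyl, a ring such as cyclopentyl, or a chain ending in an amine or a carboxylic acid in place of propyl would give a step beyond the scatter. On these data alone, whether methyl at this carbon behaves the same way on a different core also remains open.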